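The source may report more compounds than this note shows. Statements on the series, on what has been measured and on what is new or still open speak of the compounds shown alone.

Working notes on the series. Compound 1 `COC(=O)C1=C(c2ccc(OC(F)(F)F)cc2)CCC1` carries a trifluoromethoxy group on its aromatic ring; in an assay on COS-1 cells for displacement of a labelled ligand from sodium-dependent dopamine transporter (Homo sapiens) (on this read-out lower numbers stand for stronger inhibition and higher numbers for weaker inhibition), compound 1 gives 2650000 nM, a very weak result on the scale of this read-out. Compound 2 `COC(=O)C1=C(c2ccc(S(C)(=O)=O)cc2)CCC1` carries a methylsulfonyl group at the same place; in this assay compound 2 gives "not determined" (no result reported), so no single number stands for compound 2 and nothing can be said about where it falls relative to compound 1. Compound 3 `COC(=O)C1=C(c2ccc(C(C)=O)cc2)CCC1` has not yet been measured. It differs from compound 2 in one place: acetyl in place of methylsulfonyl on an aromatic carbon. For the measured compounds named here, no step between two measured compounds is known, so the size of the step from compound 2 to compound 3 in this assay cannot be anchored; with only the result of compound 1 as a reference, any step is expected to be small, in either direction, and most likely not beyond the usual scatter. On that basis compound 3 is expected to give about 1500000 nM in this assay, within a range of 150000 nM to 15000000 nM, pending the measurement.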

Compound 3, inhibition constant: 335000 nM
Compound 3: the middle estimate sits 4.5-fold (0.65 log units) above what was measured; the range from low to high includes it.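

In this assay, for the compounds shown here, acetyl in place of trifluoromethoxy, on the aromatic carbon para to a group of 9 heavy atoms, gives a 7.9-fold lower number from compound 1 to compound 3 (0.90 log units; beyond the scatter) as the first step that can be read. The number at this place therefore depends on the group it carries, at least for these two groups, although compound 3 at 335000 nM still sits high on this read-out. No measurement at hand bears on why acetyl gives the lower number here.

Steps that involve compound 2 cannot be read, since no single number stands for it, so methylsulfonyl remains unplaced against both acetyl and trifluoromethoxy, and one readable step between two groups gives no trend. Also open, on these data alone, is how an amine, a carboxylic acid or a longer chain such as propanoyl at this place would compare with acetyl, and whether any group here could bring the number down much further on the shared core.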